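The source may report more compounds than this note shows. Statements on the series, on what has been measured and on what is new or still open speak of the compounds shown alone.

Compound 1 `O=C(Nc1ccc(OC(F)F)cc1)c1cccc(/C=C2\CC(=O)N(c3ccccc3)C2=O)c1` was tested in an ADME assay on HCT-116 cells (Homo sapiens) for cytotoxicity, read by MTT assay, with a stated time of 72 h; on this read-out lower numbers stand for stronger inhibition and higher numbers for weaker inhibition. In this assay compound 1 gives only a limit of the assay, > 100000 nM, and no number is known for it. Compound 2 `COc1ccc(NC(=O)c2cccc(CC3CC(=O)N(c4ccc(C)cc4)C3=O)c2)cc1` also gives only a limit in this assay, namely > 100000 nM. So compound 1 stands at the limit of > 100000 nM in this assay, at which 2 of the 2 values shown sit, and neither of the two values shown is a true number. Compound 3 `O=C(Nc1ccc(Cl)cc1)c1cccc(/C=C2\CC(=O)N(c3ccccc3)C2=O)c1` has not yet been measured in this assay. It differs from compound 1 in one place: chloro in place of difluoromethoxy on an aromatic carbon. Among the compounds with values here, no step between measured compounds is known here, so the expectation rests on the two limits alone. The step of a number no higher from compound 1 to compound 3 (the limit leaves the size open) is expected to be none beyond the usual scatter. Compound 3 is therefore estimated to give about 100000 nM, somewhere between 30000 nM and 300000 nM, and most likely it too will be reported only as a limit rather than a number.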

Compound 3, half-maximal inhibitory concentration: > 100000 nM
Compound 3 ended at the assay's limit; the forecaster's own chance of this, stated with the estimate: 80%; the middle value lies on the limit itself.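

In this assay compound 3 gives > 100000 nM, a limit of the assay and not a number. Compound 1 also gives only a limit, so no step can be read between compound 1 and compound 3. The compounds shown leave open whether chloro and difluoromethoxy differ at all here, and what true value any of them has: the limit of > 100000 nM in this assay, at which 3 of the 3 values shown sit.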